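From dimethylamino to piperidin-1-yl at the assay limit

A few compounds are considered here, and "the series" means these few. Any claim that something is new, unique, unknown or untested is made for them only; others in the source may bear on it.

Measured in a functional assay on SMMC-7721 cells (Homo sapiens) for antiproliferative activity, read by MTT assay, with a stated time of 48 h; on this read-out lower numbers stand for stronger inhibition and higher numbers for weaker inhibition:
- Compound 1 `Cn1cc(C2=C(c3nn(CCCn4cccc4)c4ncccc34)C(=O)NC2=O)c2ccccc21`: > 100000 nM, a limit
- Compound 2 `Cn1cc(C2=C(c3nn(CCCN4CCCCC4)c4ncccc34)C(=O)N(c3ccc(Cl)cc3)C2=O)c2ccccc21`: > 100000 nM, a limit
- Compound 3 `CN(C)CCCn1nc(C2=C(c3cn(C)c4ccccc34)C(=O)NC2=O)c2cccnc21`: > 100000 nM, a limit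

Compound 3 stands at the limit of > 100000 nM in this assay, at which 3 of the 3 values shown sit, so it has a limit and no number. Compound 4 `Cn1cc(C2=C(c3nn(CCCN4CCCCC4)c4ncccc34)C(=O)NC2=O)c2ccccc21` carries piperidin-1-yl in place of dimethylamino on a saturated chain carbon, three bonds along the chain from an aromatic nitrogen. Among the compounds with values here, the one measured step that bears on this change is a step that the two limits leave unreadable from compound 1 to compound 3, which offers no size or direction. Compound 2 carries 3-(piperidin-1-yl)propyl and gives > 100000 nM, again a limit. In this assay, the expected step is a number no higher from compound 3 to compound 4 (the limit leaves the size open), so no change beyond the scatter is expected. Compound 4 is estimated at 100000 nM, with an expected range from 40000 nM to 200000 nM.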

Compound 4, half-maximal inhibitory concentration: 7670 nM
Estimate against measurement, compound 4: 13-fold (1.12 log units) above; measured number outside the range, below it.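

In this assay this chain position now shows a readable effect: piperidin-1-yl in place of dimethylamino gives an at least 13-fold lower number from compound 3 to compound 4 (1.11 log units; beyond the scatter), and in place of 1H-pyrrol-1-yl it gives an at least 13-fold lower number from compound 1 to compound 4 (1.11 log units; beyond the scatter). Piperidin-1-yl does not suffice alone, as hydrogen in place of 4-chlorophenyl on the amide-type nitrogen gives an at least 13-fold lower number from compound 2 to compound 4 (1.11 log units; beyond the scatter). The step between the two limits cannot be read, and the other compounds remain at a limit: the limit of > 100000 nM in this assay, at which 3 of the 4 values shown sit.

On these data alone, the full size of each new step stays open, as each starts from a limit. Also open, as far as these compounds go, is what morpholin-4-yl or a longer chain carrying piperidin-1-yl would give in this assay.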